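Shifting the Fluorine Around the Pendant Phenyl Ring

A few compounds are considered here, and "the series" means these few. Any claim that something is new, unique, unknown or untested is made for them only; others in the source may bear on it.

Compound 3 `O=S(=O)(c1cc(Cl)cc(Cl)c1)c1cnc2cc(F)ccc2c1-c1ccccc1F` gives 0.93 mL/min in an ADME assay on microsomes from liver (Homo sapiens) for metabolic stability, tested at 2.5 uM (a lower number here means slower removal, a higher number faster removal of the compound), the smallest of the three numbers recorded so far, although compound 1 `O=S(=O)(c1ccc(F)cc1)c1cnc2cc(F)ccc2c1-c1ccc(F)cc1` at 1.34 mL/min sits within the scatter of it. Compound 2 `Cc1ccc(S(=O)(=O)c2cnc3cc(F)ccc3c2-c2ccc(F)cc2)cc1C` at 9.25 mL/min stands well beyond both. Among the compounds with values here, the only single-point step among the measured compounds is a 6.9-fold higher number from compound 1 to compound 2 (0.84 log units; beyond the scatter), and that step changes the group on the sulfonyl sulfur, a different part of the molecule from the one altered here. Compound 4 `O=S(=O)(c1cc(Cl)cc(Cl)c1)c1cnc2cc(F)ccc2c1-c1ccc(F)cc1` differs from compound 3 only in the pendant ring: 4-fluorophenyl in place of 2-fluorophenyl on an aromatic carbon. Within the data shown here, no measured step touches this ring, so nothing in the set points to a shift in either direction, and the closeness of compound 3 to compound 1 in this assay suggests the shared core tolerates small changes at this end. The step from compound 3 to compound 4 is therefore expected to stay within the scatter, a 1.2-fold higher number from compound 3 to compound 4 (0.07 log units; within the scatter). Compound 4 is estimated at 1.1 mL/min, with a range from 0.5 mL/min to 2.5 mL/min.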

Compound 4, intrinsic clearance in a liver preparation (reported as CLH), per the amount of preparation that the assay uses: 0.18 mL/min
The estimate for compound 4 lay 6.1-fold (0.79 log units) above the measured number; measured number below the stated range.
By their numbers in this assay, from the lowest: compound 4; then compounds 3 and 1 (each within the scatter of the next); then compound 2.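

In this assay, the pendant ring turns out not to be a silent position: with 4-fluorophenyl in place of 2-fluorophenyl, the two compounds hold the same atoms, yet the change gives a 5.2-fold lower number from compound 3 to compound 4 (0.71 log units; beyond the scatter). With the 4-fluorophenyl ring held constant, the group on the sulfonyl sulfur also matters, since 3,5-dichlorophenyl gives a 7.4-fold lower number from compound 1 to compound 4 (0.87 log units; beyond the scatter) and a 51-fold lower number from compound 2 to compound 4 (1.71 log units; beyond the scatter), so changes at both ends of the molecule move this number. No measured property is at hand that bears on the shift of the fluorine.

Going by these compounds, whether an unsubstituted phenyl ring, or a pendant ring bearing a methoxy group or a chlorine, would fall nearer compound 3 or compound 4 remains open. On these data alone, it is also open whether moving the fluorine gives a step of this size when the group on the sulfonyl sulfur is 4-fluorophenyl or 3,4-dimethylphenyl rather than 3,5-dichlorophenyl.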